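The source may report more compounds than this note shows. Statements on the series, on what has been measured and on what is new or still open speak of the compounds shown alone.

Measured in a functional assay on COLO 205 cells (Homo sapiens) for inhibition, read by sulforhodamine B assay; a lower number here means a stronger inhibitor of growth, a higher number a weaker inhibitor of growth:

- compound 1 `Cc1ccc2[nH]c(-c3ccc(-c4ccc(-c5cccc(Cl)c5)cc4)cc3)nc2c1`: 2780 nM
- compound 2 `COc1cc(-c2ccc(-c3ccc(-c4nc5cc(C)ccc5[nH]4)cc3)cc2)cc(OC)c1OC`: 190 nM
- compound 3 `FC(F)(F)c1ccc(-c2ccc(-c3ccc(-c4nc5ccccc5[nH]4)cc3)cc2)cc1`: 33900 nM

Compound 3, at 33900 nM, has the highest number of this set and is thus the weakest inhibitor of growth here, with its gaps to compound 1 and compound 2 both beyond the scatter. The next compound, compound 4 `CN(C)c1ccc(-c2ccc(-c3ccc(-c4nc5ccccc5[nH]4)cc3)cc2)cc1`, has not yet been measured. It keeps the core of compound 3 and changes only the outer group, with dimethylamino in place of trifluoromethyl on an aromatic carbon. Among the compounds with values here, no two measured compounds differ in one place only, so no measured step speaks directly to this change. The closest guide is that compound 1 gives 2780 nM and compound 2 gives 190 nM, and neither carries trifluoromethyl. Both also carry a methyl group on the core that compound 3 and compound 4 lack, which leaves the estimate loose. A large move toward stronger inhibition is therefore expected, and the expected step is a 19-fold lower number from compound 3 to compound 4 (1.27 log units; beyond the scatter). For compound 4 the estimated value is 1800 nM, with an expected range from 250 nM to 13000 nM.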

Compound 4, concentration for 50% growth inhibition: 100000 nM
Beside the measured number, compound 4's estimate is 56-fold (1.74 log units) below it; measured number above the stated range.
By their numbers in this assay, from the lowest: compound 2; then compound 1; then compound 3; then compound 4.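

In this assay, within the data shown here, the change from 4-(trifluoromethyl)phenyl to 4-(dimethylamino)phenyl gives a 2.9-fold higher number from compound 3 to compound 4 (0.47 log units; beyond the scatter), the first comparison in this set in which only one place differs. It shows that the group at this position, para to a large group, does register in growth inhibition, with a step that is modest but beyond the scatter. It also shows that, on the core shared by compound 3 and compound 4, giving up trifluoromethyl does not by itself produce a stronger inhibitor of growth: with dimethylamino in its place the inhibitor is weaker, and no measurement at hand accounts for this direction.

The compounds shown leave open how a primary amine or a carboxylic acid at this same position would compare with trifluoromethyl and dimethylamino. They also leave open whether the same exchange would give a step of similar size and direction on the core that carries the methyl group found in compound 1 and compound 2.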